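Chloro in place of methoxy: working notes on the series

The source may report more compounds than this note shows. Statements on the series, on what has been measured and on what is new or still open speak of the compounds shown alone.

Measured so far in a functional assay on MOLT-4 cells (Homo sapiens) for antiproliferative activity, read by MTT assay, with a stated time of 48 h; a lower number here means a stronger inhibitor, a higher number a weaker inhibitor
compound 1 `COc1cccc2ccc(CNCc3ccc(/C=C/C(=O)NO)cc3)nc12` gives 190 nM
compound 2 `COc1ccc2nc(CNCc3ccc(/C=C/C(=O)NO)cc3)ccc2c1` gives 230 nM

Compound 2 lies within the scatter of compound 1, so the two cannot be told apart on these numbers. Compound 3 `O=C(/C=C/c1ccc(CNCc2ccc3cc(Cl)ccc3n2)cc1)NO` differs from compound 2 by chloro in place of methoxy on an aromatic carbon. Within the data shown here, no measured pair shows this change, so the expectation rests only on compound 1 (190 nM) and compound 2 (230 nM). In this assay the estimated step of a 1.3-fold lower number from compound 2 to compound 3 (0.11 log units; within the scatter) is expected to stay within the scatter, with no firm direction. Compound 3 is estimated at 180 nM, within an expected range of 70 nM to 450 nM.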

Compound 3, half-maximal inhibitory concentration: 250 nM
Estimate against measurement, compound 3: 1.4-fold (0.14 log units) below; low and high end bracket the measured number.
By their numbers in this assay, from the lowest: compounds 1, 2 and 3 (each within the scatter of the next).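

In this assay, among these compounds, chloro in place of methoxy on an aromatic carbon gives a 1.1-fold higher number from compound 2 to compound 3 (0.04 log units; within the scatter), the only measured pair for this change so far. At this position, the methoxy with its hydrogen-bond acceptor can therefore be exchanged for chloro with no step beyond the scatter. No measured property bears on this result.

On these data alone, whether an amine, a carboxylic acid or a longer chain on this carbon would stay within the scatter remains open. So does whether chloro in place of methoxy gives a similar step from compound 1.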